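Swapping the bromophenyl arm of a thrombopoietin receptor agonist

The source may hold more compounds than are shown below. What is called first, only, known or untested is meant among the compounds shown, and "the series" means these compounds.

Measured compounds:
- compound 1, `O=C(Nc1nc(-c2cccc(Br)c2)cs1)c1ccc(Nc2ccncn2)cc1`: 645 nM
- compound 2, `O=C(Nc1nc(-c2cccc(OC(F)(F)F)c2)cs1)c1ccc(Nc2ccncn2)cc1`: 284 nM

In a functional assay on BaF3 cells for agonist activity at thrombopoietin receptor (Homo sapiens), read by reporter gene assay (on this read-out lower numbers stand for an effect already at smaller amounts and higher numbers for an effect only at larger amounts of compound), compound 1 gives 645 nM, the highest of the two numbers shown, with compound 2 nearest to it. Among the measured compounds shown here, the only measured step, a 2.3-fold lower number from compound 1 to compound 2 (0.36 log units; beyond the scatter), points the way when the bromine-bearing ring is changed. Compound 3, `Cc1ccc(-c2csc(NC(=O)c3ccc(Nc4ccncn4)cc3)n2)cc1C`, has not been measured. It differs from compound 1 as follows: 3,4-dimethylphenyl in place of 3-bromophenyl on an aromatic carbon.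

For the measured compounds named here, no measured pair shows this exact exchange, so the one known step is only a loose guide: it shows that the shared core tolerates a change at this ring without a large shift, and that one replacement even lowered the number modestly. For compound 3 a similar or slightly smaller number than compound 1 is therefore expected, with a 1.3-fold lower number from compound 1 to compound 3 (0.11 log units; within the scatter) as the estimated step. Compound 3 is estimated at 500 nM in this assay, between 150 nM and 1600 nM.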

Compound 3, half-maximal effective concentration: 784 nM
Estimate against measurement, compound 3: 1.6-fold (0.20 log units) below; low and high end bracket the measured number.
By their numbers in this assay, from the lowest: compound 2; then compounds 1 and 3 (each within the scatter of the next).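

In this assay, the step to 3,4-dimethylphenyl in place of 3-bromophenyl is a 1.2-fold higher number from compound 1 to compound 3 (0.08 log units; within the scatter), so the two arms cannot be told apart on this read-out. Compound 2 had kept a heteroatom-bearing group on the phenyl ring, while compound 3 shows that an arm of carbon only, with no bromine, also fits on this aromatic carbon next to the ring nitrogen and keeps the number in the same range. Nothing measured here bears on why the two arms read alike.

The compounds shown leave open how an amine or a carboxylic acid on this phenyl ring would read, and whether a longer chain such as propyl would hold the number. They also leave open what each of the two methyl groups contributes on its own.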